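Series notes: 2-nitrophenyl to 2,4-dimethylphenyl

This account rests on a few compounds, and the source may have more. Where it says the series, first, only, none or still open, it means among the compounds named here.

- compound 1 `Cc1cc(S(N)(=O)=O)ccc1NC(=O)COc1ccc(Cl)cc1NC(=O)c1ccccc1C`: 67300 nM
- compound 2 `Cc1ccc(C(=O)Nc2cc(Cl)ccc2OCC(=O)Nc2ccc(S(N)(=O)=O)cc2C)cc1`: 54200 nM
- compound 3 `Cc1cc(S(N)(=O)=O)ccc1NC(=O)COc1ccc(Cl)cc1NC(=O)c1ccccc1[N+](=O)[O-]`: 54800 nM

All three values come from a functional assay on C8166 cells (Homo sapiens) for cytotoxicity, read by MTT assay; on this read-out higher numbers stand for lower toxicity in this test and lower numbers for higher toxicity in this test. The three compounds cannot be ordered on these numbers, and compound 3 at 54800 nM sits within the scatter of both others. The next compound to be read is compound 4 `Cc1ccc(C(=O)Nc2cc(Cl)ccc2OCC(=O)Nc2ccc(S(N)(=O)=O)cc2C)c(C)c1`, with 2,4-dimethylphenyl in place of 2-nitrophenyl on a carbonyl carbon.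

For the measured compounds named here, three measured steps bear on this change, all at the same place on the shared core. Moving the methyl group gave a 1.2-fold lower number from compound 1 to compound 2 (0.09 log units; within the scatter). Nitro in place of methyl gave a 1.2-fold lower number from compound 1 to compound 3 (0.09 log units; within the scatter). The change from 4-methylphenyl to 2-nitrophenyl gave a 1.0-fold higher number from compound 2 to compound 3 (0.00 log units; within the scatter). None of these goes beyond the scatter, so no change at this place has yet shifted the number. Going by the values given here, no measured compound carries 2,4-dimethylphenyl, so the estimate extends these steps to a group not yet tested. In this assay no step beyond the scatter is expected, and the estimated step is a 1.1-fold higher number from compound 3 to compound 4 (0.02 log units; within the scatter). For compound 4 the expected value is 58000 nM, with an estimated range of 36000 nM to 93000 nM.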

Compound 4, half-maximal cytotoxic concentration: 47600 nM
The estimate for compound 4 lay 1.2-fold (0.09 log units) above the measured number; low and high end bracket the measured number.
By their numbers in this assay, from the lowest: compounds 4, 2, 3 and 1 (each within the scatter of the next).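

In this assay, a second methyl group on the phenyl ring attached to the carbonyl carbon leaves the number within the scatter of both single-methyl compounds, with a 1.1-fold lower number from compound 2 to compound 4 (0.06 log units; within the scatter) and a 1.4-fold lower number from compound 1 to compound 4 (0.15 log units; within the scatter), so this ring now tolerates two methyl groups as well as one in this test. Exchanging 2-nitrophenyl, which carries nitrogen and oxygen atoms, for the all-carbon 2,4-dimethylphenyl also stays within the scatter, with a 1.2-fold lower number from compound 3 to compound 4 (0.06 log units; within the scatter), and this extends the flat picture at this place to all four groups shown. Nothing on hand explains why the numbers stay this close together.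

The compounds shown carry only methyl and nitro on this ring, so it remains open whether an amine, a carboxylic acid or a longer chain there would give a step beyond the scatter. It also remains open whether a change elsewhere on the shared core would move the number at all, since every step shown here lies at this one place or within this one ring.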